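Chloro for fluoro on the terminal phenyl: compound 4

The compounds below may be only part of what the source reports. "The series", "measured", "known", "first", "only" and "open" are said of these compounds alone.

Measured in a functional assay on MKN-45 cells (Homo sapiens) for cytotoxicity, read by MTT assay, with a stated time of 72 h; a higher number here means a weaker inhibitor, a lower number a stronger inhibitor:
compound 1, `CN(C)CCNc1nc(-c2ccc(NC(=O)Nc3ccccc3Cl)cc2)nc2ccsc12`: 850 nM
compound 2, `CCN(CC)CCCNc1nc(-c2ccc(NC(=O)Nc3ccc(F)cc3)cc2)nc2ccsc12`: 470 nM
compound 3, `CCN(CC)CCCNc1nc(-c2ccc(NC(=O)Nc3ccccc3F)cc2)nc2ccsc12`: 580 nM

Compound 3 gives the second highest of the three numbers; its nearest neighbour is compound 2, within the scatter, and its furthest is compound 1, also within the scatter. Compound 4, `CCN(CC)CCCNc1nc(-c2ccc(NC(=O)Nc3ccccc3Cl)cc2)nc2ccsc12`, differs from compound 3 by chloro in place of fluoro on an aromatic carbon. Going by the values given here, no measured step swaps one halogen for another at a single place. Among the compounds with values here, the only single-place step, a 1.2-fold higher number from compound 2 to compound 3 (0.09 log units; within the scatter), moves fluoro and stays within the scatter. Compound 1 carries chloro at the same place but also a different chain, so only its value and that of compound 3 can be set side by side, and they lie within the scatter. For compound 4 the expected step is a 1.0-fold higher number from compound 3 to compound 4 (0.01 log units; within the scatter), nothing beyond the scatter. Compound 4 is estimated at 600 nM, range 300 nM to 1200 nM.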

Compound 4, half-maximal inhibitory concentration: 390 nM
Estimate against measurement, compound 4: 1.5-fold (0.19 log units) above, and the stated range covers the measured number.
By their numbers in this assay, from the lowest: compounds 4, 2, 3 and 1 (each within the scatter of the next, the first and the last beyond it).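

Working notes: in this assay, chloro for fluoro on an aromatic carbon ortho to a large group stays within the scatter (a 1.5-fold lower number from compound 3 to compound 4 (0.17 log units; within the scatter)), as does 2-chlorophenyl in place of 4-fluorophenyl (a 1.2-fold lower number from compound 2 to compound 4 (0.08 log units; within the scatter)), so these halogen changes on the terminal phenyl do not separate the compounds. Only the chain change reads beyond the scatter, with (diethylamino)methyl in place of dimethylamino (a 2.2-fold lower number from compound 1 to compound 4 (0.34 log units; beyond the scatter)), a modest step resting on this single pair. No evidence on hand accounts for either result.

Open, on these data alone, is whether bromo or methoxy at this place would read differently from chloro. Also open, as far as these compounds go, is whether a longer chain or a morpholine at the chain end would keep the step seen with the (diethylamino)methyl chain.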